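The source may hold more compounds than are shown below. What is called first, only, known or untested is meant among the compounds shown, and "the series" means these compounds.

Of the compounds shown here, three sharing one core have been measured so far. In a functional assay on A549 cells (Homo sapiens) for antiproliferative activity, read by MTT assay, with a stated time of 72 h (a higher number here means a weaker inhibitor, a lower number a stronger inhibitor), compound 1 `O=C(N/N=C/c1cccc(Br)c1)Nc1ccc(Oc2ccnc3[nH]ccc23)c(F)c1` gives 2220 nM, compound 2 `O=C(N/N=C/c1ccc(Br)cc1)Nc1ccc(Oc2ccnc3[nH]ccc23)c(F)c1` gives 820 nM, and compound 3 `O=C(N/N=C/c1cccc([N+](=O)[O-])c1)Nc1ccc(Oc2ccnc3[nH]ccc23)c(F)c1` gives 3640 nM. The value of compound 3 cannot be told apart from the first of these, but it stands clear of the second: there is a 1.6-fold higher number from compound 1 to compound 3 (0.21 log units; within the scatter), against a 4.4-fold higher number from compound 2 to compound 3 (0.65 log units; beyond the scatter).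

Compound 4 `O=C(N/N=C/c1ccc([N+](=O)[O-])cc1)Nc1ccc(Oc2ccnc3[nH]ccc23)c(F)c1` has the same atoms as compound 3, joined differently: 4-nitrophenyl in place of 3-nitrophenyl on a carbon with a double bond to nitrogen. In short, 4-nitrophenyl stands in place of 3-nitrophenyl on a carbon with a double bond to nitrogen. The same change has been measured once, with bromo instead of nitro, and there is a 2.7-fold lower number from compound 1 to compound 2 (0.43 log units; beyond the scatter). That is a single pair, and nothing yet shows that it carries over to the nitro compounds. Even so, a modest step towards a lower number is expected in this assay. The expected change is a 2.4-fold lower number from compound 3 to compound 4 (0.39 log units; beyond the scatter). The estimate for compound 4 is 1500 nM, within a range of 600 nM to 3600 nM.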

Compound 4, half-maximal inhibitory concentration: 20 nM
Compound 4: middle estimate off by 75-fold (1.88 log units), on the high side, and the stated range ends above it.
By their numbers in this assay, from the lowest: compound 4; then compound 2; then compounds 1 and 3 (each within the scatter of the next).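

Moving nitro from 3-nitrophenyl to 4-nitrophenyl does far more than the same move made with bromo: in this assay there is a 180-fold lower number from compound 3 to compound 4 (2.26 log units; beyond the scatter) and so the place of a group on this phenyl ring cannot be judged apart from which group it is. With the group in 4-nitrophenyl, nitro in place of bromo also counts heavily, giving a 41-fold lower number from compound 2 to compound 4 (1.61 log units; beyond the scatter) and, with both changes together, a 110-fold lower number from compound 1 to compound 4 (2.05 log units; beyond the scatter) as the widest gap to a bromo compound. Nitro in place of bromo therefore has no single fixed effect at this place, and its size depends on the arrangement on the ring: the same change on two cores in this assay, a 1.6-fold higher number (0.21 log units; within the scatter) from compound 1 to compound 3 and a 41-fold lower number (1.61 log units; beyond the scatter) from compound 2 to compound 4, 67-fold (1.83 log units) apart, beyond the scatter of two such steps.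

On these data alone, whether a nitrile or an amine in place of the nitro of 4-nitrophenyl would keep so low a number stays open. The large drop also rests on compound 4 alone.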